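The source may report more compounds than this note shows. Statements on the series, on what has been measured and on what is new or still open speak of the compounds shown alone.

Measured so far in an assay on HEK293 cells for inhibition of Voltage-dependent N-type calcium channel subunit alpha-1B (Homo sapiens), read by FLIPR and calcium flux; on this read-out higher numbers stand for weaker inhibition and lower numbers for stronger inhibition:
compound 1 `CS(=O)(=O)c1ccc(C(=O)N2CCC(N(C3CC3)S(=O)(=O)c3cccc(C(F)(F)F)c3)CC2)c(F)c1` gives 350 nM
compound 2 `CS(=O)(=O)c1ccc(C(=O)N2CCC(N(C3CC3)S(=O)(=O)c3cccc(C(F)(F)F)c3)CC2)c(Cl)c1` gives 290 nM
compound 3 `CS(=O)(=O)c1ccc(C(=O)N2CCC(N(C3CC3)S(=O)(=O)c3cccc(C(F)(F)F)c3)CC2)c(OC(F)(F)F)c1` gives 48 nM

Compound 3 stands lowest of the three numbers in this assay. The nearest is compound 2, and the steps of a 6.0-fold lower number from compound 2 to compound 3 (0.78 log units; beyond the scatter) and a 7.3-fold lower number from compound 1 to compound 3 (0.86 log units; beyond the scatter) both lie beyond the scatter. The step of a 1.2-fold lower number from compound 1 to compound 2 (0.08 log units; within the scatter) is within the scatter, so compounds 1 and 2 are not told apart.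

Compound 4 `NC(=O)c1ccc(C(=O)N2CCC(N(C3CC3)S(=O)(=O)c3cccc(C(F)(F)F)c3)CC2)c(OC(F)(F)F)c1` is not yet measured. Its change from compound 3: carbamoyl in place of methylsulfonyl on an aromatic carbon. None of the three measured steps touches this place; each of them swaps the group on the other aromatic carbon, with the methylsulfonyl kept throughout. Among the measured compounds shown here, the measured set therefore gives no step of the same kind to lean on, and the expectation rests only on the shared core and the trifluoromethoxy that compound 4 has in common with compound 3, whose value in this assay is 48 nM.

For the measured compounds named here, with no matching step in hand, the number for compound 4 is expected to stay close to that of compound 3, shifted at most modestly and with a wide range. Compound 4 is expected at 100 nM in this assay, between 30 nM and 350 nM, which means an expected step of a 2.1-fold higher number from compound 3 to compound 4 (0.32 log units; beyond the scatter).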

Compound 4, half-maximal inhibitory concentration: 390 nM
Beside the measured number, compound 4's estimate is 3.9-fold (0.59 log units) below it, and the stated range ends below it.
By their numbers in this assay, from the lowest: compound 3; then compounds 2, 1 and 4 (each within the scatter of the next).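

Within this assay, the aromatic carbon para to a large group and meta to a trifluoromethoxy group now has its first measured step, and it is not a silent place: carbamoyl in place of methylsulfonyl gives an 8.1-fold higher number from compound 3 to compound 4 (0.91 log units; beyond the scatter). The earlier steps shown here all kept the methylsulfonyl and changed only the other aromatic carbon, so this result shows that the number depends on the group at this position as well, at least with trifluoromethoxy on the ring. The exchange replaces a group with no hydrogen-bond donor by one that has a hydrogen-bond donor, but that difference is only a count, and no measurement at hand bears on what drives the step.

A single exchange cannot separate the role of the amide hydrogen from that of the rest of the group, and groups such as a nitrile, a carboxylic acid or an N-methyl carbamoyl would each test a different part of the question. Going by these compounds, it also remains open whether carbamoyl in place of methylsulfonyl gives a step of similar size with fluoro or chloro on the other aromatic carbon.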